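The compounds below may be only part of what the source reports. "The series", "measured", "known", "first", "only" and "open" are said of these compounds alone.

Compound 2 `Cc1c(F)c(Oc2cccc(C(=N)N)c2)nc(Oc2cccc(N(C)C)c2)c1F` and compound 1 `N=C(N)c1ccc(Oc2nc(Oc3ccc(C(=N)N)cc3)c(Cl)cc2Cl)cc1` share a core carrying two aryl ethers. In an assay on isolated protein for inhibition of serine protease 1 (Bos taurus) (a lower number here means a stronger inhibitor, a higher number a weaker inhibitor), compound 2 gives 1900 nM, the lower of the two numbers recorded, while compound 1 gives 2700 nM; the gap between them lies within the scatter, so neither can be called the stronger inhibitor. Compound 3 `Cc1c(F)c(Oc2cccc(C(=N)N)c2)nc(Oc2cccc(C(N)=O)c2)c1F` is compound 2 with carbamoyl in place of dimethylamino on an aromatic carbon. Within the data shown here, no measured pair isolates this change, so the step from compound 2 to compound 3 can only be judged from the change itself; it is expected to be small, a 1.3-fold higher number from compound 2 to compound 3 (0.12 log units; within the scatter), and not beyond the scatter. For compound 3 the estimate is 2500 nM, within 800 nM to 8000 nM.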

Compound 3, inhibition constant: > 5000 nM
Compound 3 ended at the assay's limit; the forecaster's own chance of this, stated with the estimate: 5%; at least 2.0-fold (0.30 log units) between middle value and limit.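

In this assay, compound 3 gives > 5000 nM, which is a limit of the assay and not a number. Even so, the change from 3-(dimethylamino)phenyl to 3-carbamoylphenyl is not silent, with an at least 2.6-fold higher number from compound 2 to compound 3 (0.42 log units; beyond the scatter), so the number at this position depends on the group carried there. That step gives only a minimum size: the limit of > 5000 nM in this assay, at which 1 of the 3 values shown sits.

From the compounds shown here alone, how far compound 3 lies past the limit stays open. So does whether a primary amine, a carboxylic acid or a longer chain at this position would stay close to compound 2 or move as carbamoyl does.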